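A Methyl Added to the Chain of Compound 3

A few compounds are considered here, and "the series" means these few. Any claim that something is new, unique, unknown or untested is made for them only; others in the source may bear on it.

Of the compounds shown here, three have been read in a functional assay on MT4 cells (Homo sapiens) for cytotoxicity; a lower number here means that less compound is tolerated, a higher number that more compound is tolerated. Compound 1 (`Cc1c(Cc2c(F)cccc2F)nc(SC(C)C)[nH]c1=O`) stands at > 200000 nM which is a limit of the assay. Compound 2 (`CCC(C)Sc1nc(O)c(C)c(Cc2c(F)cccc2F)n1`) gives 200000 nM as a number. Compound 3 (`CC(C)Sc1nc(O)cc(C(C)c2ccccc2)n1`) stands at > 200000 nM which is also a limit. It therefore sits at the limit of > 200000 nM in this assay, at which 2 of the 3 values shown sit, and has no exact number. Compound 4 (`CCC(c1ccccc1)c1cc(O)nc(SC(C)C)n1`) differs from compound 3 by one change (methyl in place of hydrogen on a saturated chain carbon, two bonds along the chain from two aromatic carbons) which reads methyl to ethyl when cut one bond further out. For the measured compounds named here, no measured pair shows this change, and no step beyond the scatter is expected in this assay in either direction. The estimated step of a number no higher from compound 3 to compound 4 (the limit leaves the size open) stays within that scatter. Going by the values given here, this expectation leans on compound 2 at 200000 nM as the only exact number available. Compound 4 is expected at 200000 nM with an estimated range of 90000 nM to 400000 nM in this reading.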

Compound 4, half-maximal cytotoxic concentration: > 200000 nM
Compound 4 ended at the assay's limit; the forecaster's own chance of this, stated with the estimate: 70%; the middle value sits exactly at the limit.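

No step can be read between compound 3 and compound 4, as both rest at a limit in this assay: the limit of > 200000 nM in this assay, at which 3 of the 4 values shown sit.

The compounds shown leave open whether methyl in place of hydrogen on this chain carbon changes how much compound is tolerated.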